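Benzyl for propargyl on a triazene imidazole carboxamide

The source may report more compounds than this note shows. Statements on the series, on what has been measured and on what is new or still open speak of the compounds shown alone.

Measured so far:
compound 1, `COc1ccc(Cn2nnc3c(C(N)=O)ncn3c2=O)c(OC)c1`, > 50000 nM
compound 2, `C#CC/N=N/Nc1[nH]cnc1C(N)=O`, 39100 nM

Of the compounds shown here, two have been tested in a functional assay on SNB-19 cells (Homo sapiens) for inhibition, read by MTT assay, with a stated time of 7 days; a lower number here means a stronger inhibitor of growth, a higher number a weaker inhibitor of growth. Compound 1 (`COc1ccc(Cn2nnc3c(C(N)=O)ncn3c2=O)c(OC)c1`) reaches only > 50000 nM, which is a limit of the assay rather than a number, as recorded by the limit of > 50000 nM in this assay, at which 1 of the 2 values shown sits. For the measured compounds named here, compound 2 (`C#CC/N=N/Nc1[nH]cnc1C(N)=O`) gives 39100 nM in this assay, the only number among the two results, and it marks compound 2 as a weak growth inhibitor.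

Compound 3 (`NC(=O)c1nc[nH]c1N/N=N/Cc1ccccc1`) has not yet been measured. It differs from compound 2 by phenyl in place of ethynyl on a saturated chain carbon bound to a double-bonded nitrogen. Going by the values given here, no step between two measured compounds is available, so the size of this change cannot be read from the data. The step from compound 2 to compound 3 in this assay is expected to be small, a 1.0-fold higher number from compound 2 to compound 3 (0.01 log units; within the scatter), not beyond the scatter. Compound 3 is therefore estimated at 40000 nM in this assay, with a range from 15000 nM to 100000 nM.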

Compound 3, concentration for 50% growth inhibition: > 50000 nM
Compound 3 ended at the assay's limit; the forecaster's own chance of this, stated with the estimate: 35%; middle value at least 1.2-fold (0.09 log units) away from the limit.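

Phenyl in place of ethynyl on a saturated chain carbon bound to a double-bonded nitrogen gives the first step that can be read at this position in this assay: an at least 1.2-fold higher number from compound 2 to compound 3 (0.10 log units; that floor lies within the scatter). Compound 3 gives > 50000 nM, which is a limit of the assay and not a number. The step is therefore only a floor, so compound 2 remains the only compound with a number, and the full size of this change cannot be told: the limit of > 50000 nM in this assay, at which 2 of the 3 values shown sit.

The compounds shown leave open whether a simple methyl or a longer alkyl chain in place of ethynyl would give a lower number than compound 2 does. They also leave open what an amine or a carboxylic acid on the phenyl ring of compound 3 would do in this assay.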